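Three compounds at the same cytotoxicity limit

The compounds below may be only part of what the source reports. "The series", "measured", "known", "first", "only" and "open" are said of these compounds alone.

Compound 1, `Cn1cc(SCC(=O)NCc2ccc(Cl)c(Cl)c2)c2ccccc21`: > 100000 nM
Compound 2, `COc1ccccc1CNC(=O)CSc1cn(C)c2ccccc12`: > 100000 nM
Compound 3, `COc1ccccc1CNC(=O)CSc1c[nH]c2cccc(Br)c12`: > 100000 nM

All three measured compounds were tested in an ADME assay on HEK-293T cells (Homo sapiens) for cytotoxicity, read by CCK-8 assay, with a stated time of 24 h; a higher number here means that more compound is tolerated, a lower number that less compound is tolerated. For compound 1 the value > 100000 nM is a limit of the assay, not a number. For compound 2 the value > 100000 nM is likewise a limit. For compound 3 the value > 100000 nM is a limit as well. The change from compound 2 to compound 1 is 3,4-dichlorophenyl in place of 2-methoxyphenyl on a saturated chain carbon bound to an amide-type nitrogen, and the size of the step that the two limits leave unreadable from compound 2 to compound 1 cannot be read because of the limit of > 100000 nM in this assay, at which 3 of the 3 values shown sit. The difference between the cores of compound 2 and compound 3 is not broken down here.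

Compound 4, `O=C(CSc1c[nH]c2cccc(Br)c12)NCc1ccc(Cl)c(Cl)c1`, has not yet been measured in this assay. It arises from compound 3 by the same change, (3,4-dichlorophenyl in place of 2-methoxyphenyl on a saturated chain carbon bound to an amide-type nitrogen), at the same place. Resting on the fact that every measured value sits at the limit of > 100000 nM in this assay, at which 3 of the 3 values shown sit, the expected step is a number no higher from compound 3 to compound 4 (the limit leaves the size open). Compound 4 is therefore expected to give about 100000 nM, estimated to fall between 50000 nM and 300000 nM, most likely again reported only as a limit.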

Compound 4, half-maximal cytotoxic concentration: > 100000 nM
Compound 4: only a limit was reported; the forecaster's own chance of this, stated with the estimate: 85%; the middle value sits exactly at the limit.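

The step from compound 3 to compound 4 cannot be read, and no size can be given for it, because both values are limits and not numbers: the limit of > 100000 nM in this assay, at which 4 of the 4 values shown sit.

The compounds shown leave open how much of any of them the cells tolerate in this assay, and whether 3,4-dichlorophenyl in place of 2-methoxyphenyl changes that amount at all.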